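This account rests on a few compounds, and the source may have more. Where it says the series, first, only, none or still open, it means among the compounds named here.

Measured so far:
compound 1, `CN1CCC[C@H]1COc1cncc(-c2cccc([N+](=O)[O-])c2)c1`: 0.465 nM
compound 2, `CN1CCC[C@H]1COc1cncc(-c2cccc(N)c2)c1`: 0.43 nM

In an assay on membranes from brain for binding affinity to Neuronal acetylcholine receptor; alpha4/beta2 (Rattus norvegicus) (on this read-out higher numbers stand for weaker inhibition and lower numbers for stronger inhibition), compound 2 gives the lowest of the two numbers, and compound 1 stands within the scatter of it, so a 1.1-fold lower number from compound 1 to compound 2 (0.03 log units; within the scatter) shows no real change. Compound 3, `CN1CCC[C@H]1COc1cncc(-c2ccco2)c1`, carries furan-2-yl in place of 3-aminophenyl on an aromatic carbon. Within the data shown here, the only measured step swaps one substituent on that ring; no step covers exchanging the ring itself, so the expectation is loose. Loss of the whole ring is expected to cost somewhat, giving an estimated 3.5-fold higher number from compound 2 to compound 3 (0.54 log units; beyond the scatter) for compound 3. The value of compound 3 in this assay is estimated at 1.5 nM, within 0.4 nM to 6 nM.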

Compound 3, inhibition constant: 0.19 nM
Estimate against measurement, compound 3: 7.9-fold (0.90 log units) above, and the stated range ends above it.
By their numbers in this assay, from the lowest: compound 3; then compounds 2 and 1 (each within the scatter of the next).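

The earlier compounds shown here changed only a substituent on the aromatic ring, while this change replaces the ring itself. In this assay, furan-2-yl in place of 3-aminophenyl gives a 2.3-fold lower number from compound 2 to compound 3 (0.35 log units; beyond the scatter) and so shows that a six-membered ring of carbon is not required at this position for a low number. No available evidence explains this shift.

Going by these compounds, this single swap changes ring size, the ring oxygen and the amino group at once, so their separate contributions remain open. How a thiophene, a pyridine or an unsubstituted phenyl ring would compare is also unknown.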